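A few compounds are considered here, and "the series" means these few. Any claim that something is new, unique, unknown or untested is made for them only; others in the source may bear on it.

Compound 2 `O=C(O)Cn1c(SCCNc2ccccc2)nc2ccccc21` gives 7690 nM in an assay on HEK293 cells for displacement of a labelled ligand from prostaglandin D2 receptor 2 (Homo sapiens) (on this read-out higher numbers stand for weaker inhibition and lower numbers for stronger inhibition), the higher of the two numbers recorded; compound 1 `O=C(O)Cn1c(SCCCNc2ccccc2)nc2ccccc21` gives 2690 nM, and the step of a 2.9-fold higher number from compound 1 to compound 2 (0.46 log units; beyond the scatter) is the only measured one. Compound 3 `CCOC(=O)CCCCSc1nc2ccccc2n1CC(=O)O` differs from compound 2 by 2-(ethoxycarbonyl)ethyl in place of anilino on a saturated chain carbon, two bonds along the chain from a sulfur. Within the data shown here, no measured step exchanges a ring for an open chain, so the shortening step gives little guidance; it only marks that this part of the molecule is sensitive to change. A modest rise or no step beyond the scatter is expected, with a 1.6-fold higher number from compound 2 to compound 3 (0.19 log units; within the scatter) as the estimated step. Compound 3 is expected to give 12000 nM in this assay, within 3500 nM to 40000 nM.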

Compound 3, half-maximal inhibitory concentration: 2360 nM
For compound 3 the middle estimate is 5.1-fold (0.71 log units) above the measured one; measured number outside the range, below it.
By their numbers in this assay, from the lowest: compounds 3 and 1 (each within the scatter of the next); then compound 2.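

In this assay, the step of a 3.3-fold lower number from compound 2 to compound 3 (0.51 log units; beyond the scatter) comes with 2-(ethoxycarbonyl)ethyl in place of anilino, so at this chain carbon an aromatic ring is not needed for the lower number, and a group with no ring and 0 hydrogen-bond donors is accepted. The step of a 1.1-fold lower number from compound 1 to compound 3 (0.06 log units; within the scatter) lies within the scatter, so the ester chain of compound 3 and the anilino chain of compound 1 read alike. No measured evidence accounts for either step. Still open, from the compounds shown here alone, is how a carboxylic acid or an amine in place of the ethoxycarbonyl group would read, and how a longer chain would read.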